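The compounds below may be only part of what the source reports. "The series", "measured", "known", "first", "only" and "open" are said of these compounds alone.

Measured compounds:
Compound 1, `Cc1ccccc1NC1=C/C(=N/NC(N)=S)C(=O)N=C1Nc1ccccc1C`: 1520 nM
Compound 2, `NC(=S)N/N=C1/C=C(Nc2ccc(F)cc2)C(Nc2ccc(F)cc2)=NC1=O`: 3720 nM

Both compounds were tested in a functional assay on HCT-116 cells (Homo sapiens) for antiproliferative activity, read by MTT assay, with a stated time of 72 h (on this read-out higher numbers stand for weaker inhibition and lower numbers for stronger inhibition), which records how strongly each one slows the growth of a colon cancer cell line. Of the two numbers, compound 2 has the higher one, meaning weaker inhibition of cell growth, and compound 1 the lower one; the gap between them is wider than the usual scatter of repeated measurements, so compound 2 is the weaker of the pair on this read-out.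

Compound 3 `N/C(=N\N=C1\C=C(Nc2ccc(F)cc2)C(Nc2ccc(F)cc2)=NC1=O)SCc1ccccc1` has not yet been measured. It differs from compound 2 in a single place: a group of 11 heavy atoms (8 carbon, 2 nitrogen, 1 sulfur; one six-membered aromatic ring of carbon only) in place of a group of 4 heavy atoms (1 carbon, 2 nitrogen, 1 sulfur; no ring), on a double-bonded nitrogen. For the measured compounds named here, no pair of measured compounds differs by this same change, so there is no measured guide to its effect, and the two values at hand say nothing about it.

Compound 3 is therefore expected to show a 1.2-fold lower number from compound 2 to compound 3 (0.09 log units; within the scatter), a step that stays within the scatter and has no settled direction. The estimate for compound 3 in this assay is 3000 nM, with a likely range from 800 nM to 12000 nM.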

Compound 3, half-maximal inhibitory concentration: 11500 nM
For compound 3 the middle estimate is 3.8-fold (0.58 log units) below the measured one, and the stated range covers the measured number.
By their numbers in this assay, from the lowest: compound 1; then compound 2; then compound 3.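

For the compounds shown here, this is the first measured step at this position. On a double-bonded nitrogen, putting the group of 11 heavy atoms, with its six-membered aromatic ring, in place of the group of 4 heavy atoms with no ring gives a 3.1-fold higher number from compound 2 to compound 3 (0.49 log units; beyond the scatter) in this assay, so the change weakens growth inhibition by a modest amount that exceeds the usual variation between repeats. Nothing available explains this loss of activity.

A single step cannot separate the effect of the aromatic ring from the other differences between the two groups, and it does not show whether a methylamine group or a short ethyl chain in the same place would weaken inhibition too. It also leaves open whether the same replacement would produce a similar step on the core of compound 1, which carries a methyl group on each of its outer rings rather than fluorine.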